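A few compounds are considered here, and "the series" means these few. Any claim that something is new, unique, unknown or untested is made for them only; others in the source may bear on it.

In a functional assay on FaDu cells (Homo sapiens) for cytotoxicity, read by MTT assay, with a stated time of 72 h (a lower number here means that less compound is tolerated, a higher number that more compound is tolerated), compound 3 (`CC(C)Oc1ccc(NC(=O)C(=O)c2cn(C(C)C)c3ccccc23)cn1`) gives 408 nM, the highest of the three numbers, while compound 1 (`COc1ncc(NC(=O)C(=O)c2cn(C(C)C)c3ccccc23)cn1`) gives 171 nM and compound 2 (`COc1ccc(NC(=O)C(=O)c2cn(C(C)C)c3ccccc23)cc1`) gives 181 nM. Compound 4 (`CC(C)n1cc(C(=O)C(=O)Nc2cccnc2)c2ccccc21`) differs from compound 3 by one change, hydrogen in place of isopropoxy on an aromatic carbon. Among the compounds with values here, no measured step removes such a group. Within the data shown here, the single measured step, a 1.1-fold higher number from compound 1 to compound 2 (0.02 log units; within the scatter), exchanges one methoxy-bearing ring for another and stays within the scatter, so it offers only weak guidance. The expected change is therefore small, a 1.2-fold lower number from compound 3 to compound 4 (0.09 log units; within the scatter), and not expected to exceed the scatter. For compound 4 the estimate is 330 nM, with an expected range from 110 nM to 1000 nM.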

Compound 4, concentration lethal to 50% of the cells: > 10000 nM
Compound 4: a limit, no number; the forecaster's own chance of this, stated with the estimate: 3%; middle value at least 30-fold (1.48 log units) away from the limit.
By their numbers in this assay, from the lowest: compounds 1 and 2 (each within the scatter of the next); then compound 3. At a limit, above all of these: compound 4.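

In this assay the reading for compound 4 is a limit of the assay and not a number: the limit of > 10000 nM in this assay, at which 1 of the 4 values shown sits.

Placing hydrogen instead of isopropoxy on the aromatic carbon next to the ring nitrogen is therefore a large change, an at least 24-fold higher number from compound 3 to compound 4 (1.38 log units; beyond the scatter), whereas the earlier exchange of methoxy-bearing rings, a 1.1-fold higher number from compound 1 to compound 2 (0.02 log units; within the scatter), was not. The ring exchanges that leave no methoxy group are also large, an at least 55-fold higher number from compound 2 to compound 4 (1.74 log units; beyond the scatter) and an at least 58-fold higher number from compound 1 to compound 4 (1.76 log units; beyond the scatter).

As far as these compounds go, whether an amine or a chlorine atom on this carbon would keep the number near those of compounds 1, 2 and 3 stays open. From the compounds shown here alone, how far compound 4 lies beyond its limit also stays open.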